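The source may report more compounds than this note shows. Statements on the series, on what has been measured and on what is new or still open speak of the compounds shown alone.

Compound 3 `Nc1ncc(Cc2ccccc2F)c(N)n1` stands at the high end of the three numbers in an assay for inhibition of Dihydrofolate reductase (Gallus gallus) (on this read-out higher numbers stand for weaker inhibition and lower numbers for stronger inhibition), with 43700 nM, though its gaps to the other two are within the scatter. Compound 1 `COCc1ccccc1Cc1cnc(N)nc1N` gives 39800 nM in this assay, and compound 2 `CS(=O)(=O)Oc1ccccc1Cc1cnc(N)nc1N` gives 22900 nM. The three differ only in the group that sits on the aromatic carbon of the ring of carbon only: the step of a 1.1-fold higher number from compound 1 to compound 3 (0.04 log units; within the scatter) and the step of a 1.9-fold higher number from compound 2 to compound 3 (0.28 log units; within the scatter) both stay within the scatter, as does the step of a 1.7-fold lower number from compound 1 to compound 2 (0.24 log units; within the scatter).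

Compound 4 `Nc1ncc(Cc2ccccc2Br)c(N)n1` continues along the same position, with bromo in place of fluoro on an aromatic carbon, on an aromatic carbon of a six-membered aromatic ring of carbon only, ortho to a group of 9 heavy atoms. Every measured exchange at this place, methoxymethyl for fluoro, (methylsulfonyl)oxy for methoxymethyl, fluoro for (methylsulfonyl)oxy, left this assay unmoved beyond the scatter, and nothing among the three compounds singles out a halogen as behaving differently. On that ground the expected step of a 1.1-fold lower number from compound 3 to compound 4 (0.04 log units; within the scatter) is one of no clear size in either direction. Compound 4 is therefore estimated at 40000 nM in this assay, with a range from 15000 nM to 110000 nM.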

Compound 4, inhibition constant: 12300 nM
Beside the measured number, compound 4's estimate is 3.3-fold (0.51 log units) above it; measured number outside the range, below it.
By their numbers in this assay, from the lowest: compounds 4, 2, 1 and 3 (each within the scatter of the next, the first and the last beyond it).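

Among these compounds, the position is not as flat as the first three compounds suggested: in this assay, bromo in place of fluoro on this aromatic carbon gives a 3.6-fold lower number from compound 3 to compound 4 (0.55 log units; beyond the scatter), beyond the scatter, which no step among compound 1, compound 2 and compound 3 reached. Bromo in place of methoxymethyl gives a 3.2-fold lower number from compound 1 to compound 4 (0.51 log units; beyond the scatter), also beyond the scatter, so the two halogens are not interchangeable here and bromo stands apart from two of the other three groups. The exception is (methylsulfonyl)oxy, for which bromo gives a 1.9-fold lower number from compound 2 to compound 4 (0.27 log units; within the scatter), within the scatter, so this group cannot be separated from bromo, and no measurement at hand accounts for any of these differences.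

Going by these compounds, whether chloro or iodo on the same aromatic carbon would go with bromo or with fluoro remains open, so two halogens do not yet make a trend. Also open, on these data alone, is how an amine, a hydroxyl or a carboxylic acid at this place would read in this assay, and whether bromo would give a step of similar size on a different core.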